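The source may report more compounds than this note shows. Statements on the series, on what has been measured and on what is new or still open speak of the compounds shown alone.

Compound 1 `C/C=C/C(=O)Nc1c(C(O)(C(F)(F)F)C(F)(F)F)ccc2ccccc12` carries a prop-1-en-1-yl group on the carbonyl carbon of its amide, and in an assay on LtK cells with ATP-sensitive inward rectifier potassium channel 11 (Homo sapiens) as the target (on this read-out lower numbers stand for an effect already at smaller amounts and higher numbers for an effect only at larger amounts of compound), compound 1 gives 72 nM. Of the three compounds measured, compound 1 stands at the lowest number. Compound 2 `O=C(Nc1c(C(O)(C(F)(F)F)C(F)(F)F)ccc2ccccc12)C1CCCC1` gives 495 nM in this assay, and compound 3 `O=C(Nc1c(C(O)(C(F)(F)F)C(F)(F)F)ccc2ccccc12)c1ccccc1Cl` gives 2040 nM. Both steps away from compound 1 run upward: a 6.9-fold higher number from compound 1 to compound 2 (0.84 log units; beyond the scatter) and a 28-fold higher number from compound 1 to compound 3 (1.45 log units; beyond the scatter), and between the two ring-bearing compounds a 4.1-fold higher number from compound 2 to compound 3 (0.62 log units; beyond the scatter).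

Compound 4 `N#Cc1cccc(C(=O)Nc2c(C(O)(C(F)(F)F)C(F)(F)F)ccc3ccccc23)c1` has not yet been measured. It differs from compound 1 by 3-cyanophenyl in place of prop-1-en-1-yl on a carbonyl carbon. Among the compounds with values here, the step that bears most directly on this is the one to compound 3, where an aromatic ring entered on the same carbonyl carbon and the number rose by a 28-fold higher number from compound 1 to compound 3 (1.45 log units; beyond the scatter); the step to compound 2, a 6.9-fold higher number from compound 1 to compound 2 (0.84 log units; beyond the scatter), shows that a saturated ring on that carbon also raised the number, though by less. On this basis a higher number is expected for compound 4, beyond the scatter, with a size between those two steps or near the larger one; the expected step is a 14-fold higher number from compound 1 to compound 4 (1.14 log units; beyond the scatter). The estimate for compound 4 in this assay is 1000 nM, with a range from 300 nM to 3500 nM.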

Compound 4, half-maximal effective concentration: 12 nM
Beside the measured number, compound 4's estimate is 83-fold (1.92 log units) above it; measured number below the stated range.
By their numbers in this assay, from the lowest: compound 4; then compound 1; then compound 2; then compound 3.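

In this assay, an aromatic ring on the carbonyl carbon does not by itself raise the number: 3-cyanophenyl in place of prop-1-en-1-yl gives a 6.0-fold lower number from compound 1 to compound 4 (0.78 log units; beyond the scatter) and so runs opposite to the rise seen with 2-chlorophenyl in compound 3. Which substituted phenyl stands at this position matters a great deal, since 3-cyanophenyl in place of 2-chlorophenyl gives a 170-fold lower number from compound 3 to compound 4 (2.23 log units; beyond the scatter) and this is a wider span than any step among the earlier compounds. The saturated ring also falls behind, with a 41-fold lower number from compound 2 to compound 4 (1.62 log units; beyond the scatter) as the step from cyclopentyl to 3-cyanophenyl, so compound 4 holds the lowest number of the four, and its steps to all the others lie beyond the scatter.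

Going by these compounds, whether the fall belongs to the nitrile itself, to where it sits on the ring, or to the absence of the chlorine remains open, and an unsubstituted phenyl, or a phenyl carrying an amine or a carboxylic acid instead of the nitrile, would be needed to separate these readings. Nothing available here explains why these groups differ as they do.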